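From compound 1 to compound 3: one group exchanged

This account rests on a few compounds, and the source may have more. Where it says the series, first, only, none or still open, it means among the compounds named here.

Compound 1 `N#Cc1cnc(N2CCC(C(=O)N3N=CC[C@H]3c3cc(F)cc(F)c3)CC2)cn1`: 184 nM
Compound 2 `CC(=O)N1CCC(C(=O)N2N=CC[C@H]2c2ccccc2)CC1`: 2660 nM

In an ADME assay on the whole organism (Rattus norvegicus) for pharmacokinetics, at a dose of 2 mg/kg by the oral route (a higher number here means more compound in the circulation at the dose given, a lower number less compound in the circulation), compound 1 gives 184 nM. In this assay compound 2 gives 2660 nM. The gap between these two numbers lies beyond the usual scatter, and compound 1 has the lower number. Compound 3 `Cc1nnc(N2CCC(C(=O)N3N=CC[C@H]3c3cc(F)cc(F)c3)CC2)o1` carries 5-methyl-1,3,4-oxadiazol-2-yl in place of 5-cyanopyrazin-2-yl on an amine nitrogen in a ring. For the measured compounds named here, no measured step isolates this exchange, so its size is uncertain. Going by the values given here, the only higher reference is compound 2 at 2660 nM, so a moderate rise is expected, estimated as a 3.3-fold higher number from compound 1 to compound 3 (0.51 log units; beyond the scatter). For compound 3 the expected value is 600 nM, within an estimated range of 150 nM to 2500 nM.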

Compound 3, maximal plasma concentration: 2930 nM
Estimate against measurement, compound 3: 4.9-fold (0.69 log units) below; measured number above the stated range.
By their numbers in this assay, from the lowest: compound 1; then compounds 2 and 3 (each within the scatter of the next).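

In this assay the group on this amine nitrogen in a ring clearly matters: 5-methyl-1,3,4-oxadiazol-2-yl in place of 5-cyanopyrazin-2-yl gives a 16-fold higher number from compound 1 to compound 3 (1.20 log units; beyond the scatter) with the rest of the molecule unchanged. The earlier compounds shown here differed in more than one place, so they could not tie a gap of this size to this position alone. Nothing measured here explains the rise.

From the compounds shown here alone, it remains open whether the rise follows the loss of the nitrile, the new five-membered ring or its methyl group. A pyrimidine ring without the nitrile, or an oxadiazole carrying a cyclopropyl group, would help separate these.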